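The compounds below may be only part of what the source reports. "The series", "measured", "known", "first", "only" and "open" are said of these compounds alone.

Measured compounds: compound 1 `Clc1ncnc2c1ncn2Cc1ccccc1` with 3% in an assay on isolated protein for inhibition of Rho-associated protein kinase 1 (Homo sapiens), tested at 30 uM; on this read-out higher numbers stand for more inhibition at the one concentration tested (going by the name of the read-out) and lower numbers for less inhibition; compound 2 `Fc1ccc(Cn2cnc3c(Cl)ncnc32)cc1` with 0% in this assay; compound 3 `CSc1ccc(-c2nc3c(Sc4ccccc4)ncnc3n2C)cc1` with 0% in this assay.

In this assay compound 1 gives 3% and compound 2 gives 0%. The two share one core and differ by fluoro in place of hydrogen on an aromatic carbon; the step is a number 3 percentage points lower from compound 1 to compound 2 (within the scatter). Compound 3 belongs to a different series, and the difference between its core and the core of compound 1 is not broken down here. In this assay compound 3 gives 0%, level with compound 2 at the digits reported.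

Compound 4 `CSc1ccc(-c2nc3c(Sc4ccc(F)cc4)ncnc3n2C)cc1` has not yet been measured. It differs from compound 3 by fluoro in place of hydrogen on an aromatic carbon, which is the same change as that from compound 1 to compound 2, made at the same kind of place. As the earlier step was a number 3 percentage points lower from compound 1 to compound 2 (within the scatter), the step from compound 3 to compound 4 is expected to be a number 2 percentage points higher from compound 3 to compound 4 (within the scatter). Compound 4 is therefore estimated to give 2% in this assay, most likely between -8% and 12%.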

Compound 4, a percentage reported as inhibition, at one concentration (the size of the read-out at that concentration, not a potency): 0%
Beside the measured number, compound 4's estimate is 2 percentage points above it; low and high end bracket the measured number.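

Going from phenylsulfanyl to (4-fluorophenyl)sulfanyl gives no change at the digits printed from compound 3 to compound 4 (within the scatter) in this assay. Set beside the earlier step, the same change reads alike on the two cores: the same change on two cores in this assay, a number 3 percentage points lower (within the scatter) from compound 1 to compound 2 and no change at the digits printed (within the scatter) from compound 3 to compound 4, 3 percentage points apart, within the scatter of two such steps This does not show that the fluoro group is without effect on these cores in general: all four compounds read close to the bottom of the scale at the one concentration tested, so agreement between the two steps says little about how the change would carry over on a compound with clear inhibition.

The compounds shown leave open whether any group on these cores gives a clear reading in this assay, and whether fluoro on the same ring at another place would read differently. Whether an amine or a carboxylic acid in place of the fluoro group would move the number also remains an open question.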